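This account rests on a few compounds, and the source may have more. Where it says the series, first, only, none or still open, it means among the compounds named here.

Compound 1, `O=C(C1CC=CC1)N1CC2CC(C1)N2`: 95%
Compound 2, `O=C([C@H]1C[C@H]1F)N1CC2CC(C1)N2`: 110%

In an assay on SH-EP1 cells for agonist activity at Neuronal acetylcholine receptor; alpha4/beta2 (Homo sapiens), read by FLIPR and calcium flux (on this read-out lower numbers stand for smaller maximal responses and higher numbers for larger maximal responses), compound 2 gives the higher of the two values, and compound 1 sits lower by a gap beyond the usual scatter. Compound 3, `C[C@@H]1C[C@@H]1C(=O)N1CC2CC(C1)N2`, differs from compound 2 by methyl in place of fluoro on a saturated ring carbon. Within the data shown here, no measured pair shows this same change, so the expectation rests on compound 2 alone. A small downward step is expected, a number 10 percentage points lower from compound 2 to compound 3 (within the scatter), which may well fall within the scatter. Compound 3 is estimated at 100%, with a range from 80% to 120%.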

Compound 3, largest response reached (Emax), in percent of the reference or control that the assay uses: 97%
Beside the measured number, compound 3's estimate is 3 percentage points above it; the range from low to high includes it.
By their numbers in this assay, from the lowest: compounds 1 and 3 (each within the scatter of the next); then compound 2.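

In this assay methyl in place of fluoro on a saturated ring carbon of the three-membered ring gives a number 13 percentage points lower from compound 2 to compound 3 (beyond the scatter) and so shows that the maximal response depends, modestly, on which of these two single-atom groups sits at this position. The earlier compounds shown here offered no pair that differed only here. Nothing measured on these compounds accounts for the step.

The compounds shown leave open how a hydroxyl group, an amine or a longer chain such as ethyl would behave on this carbon. They also leave open whether the step from fluoro to methyl would hold on another core.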